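Swapping Chloro for Fluoro and Expecting Little Change

The compounds below may be only part of what the source reports. "The series", "measured", "known", "first", "only" and "open" are said of these compounds alone.

Compound 1 `Cc1occc1-c1nnc2sc(-c3ccnc(Cl)c3)nn12` gives 15.3% in a functional assay on the whole organism (strain Wistar Albino) for inhibition, with Rattus norvegicus as the target, read by paw edema, with a stated time of 2 h, at a dose of 20 mg/kg (a higher number here means more inhibition at the dose given (going by the name of the read-out), a lower number less inhibition), numerically the higher of the two numbers measured, yet compound 2 `COc1ccc(Cc2nnc3sc(-c4ccnc(F)c4)nn23)cc1OC` gives 14.3% in this assay, a gap within the usual scatter, so the two cannot be told apart. Compound 3 `Cc1occc1-c1nnc2sc(-c3ccnc(F)c3)nn12` has not been measured. It differs from compound 1 by fluoro in place of chloro on an aromatic carbon. Among the measured compounds shown here, no measured pair shows what this single change does here, so no shift beyond the scatter is expected, and the estimated step of a number 1.3 percentage points lower from compound 1 to compound 3 (within the scatter) is small. Compound 3 is expected to give 14%, between 5% and 24%.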

Compound 3, a percentage reported as inhibition, in the whole organism at one dose (the size of the read-out at that dose, not a potency): 18.2%
Compound 3: middle estimate off by 4.2 percentage points, on the low side; measured number inside the range.
By their numbers in this assay, from the lowest: compounds 2, 1 and 3 (each within the scatter of the next).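

Among the compounds shown here, the step of a number 2.9 percentage points higher from compound 1 to compound 3 (within the scatter) in this assay is the first direct reading of this swap, and it shows that fluoro and chloro cannot be told apart at this position next to the ring nitrogen. The result holds for this one pair and this one dose. Nothing available explains the result.

Still open, going by these compounds, is whether an amine or a carboxylic acid at this position would move the number beyond the scatter. On these data alone, the same swap also remains untested on the core carrying the side group of compound 2.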